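The compounds below may be only part of what the source reports. "The series", "measured", "known", "first", "only" and "open" are said of these compounds alone.

Compound 1 `C=CC(=O)Nc1cc(C(F)(F)F)cc(C(F)(F)F)c1` gives 4.2 h in an ADME assay for pharmacokinetics, read by HPLC, in phosphate buffer, with a stated time of 72 h, at pH 7.4, tested at 250 uM; on this read-out lower numbers stand for a shorter-lived compound and higher numbers for a longer-lived compound. Compound 2 `C=CC(=O)Oc1cc(C(F)(F)F)cc(C(F)(F)F)c1` reaches only the limit of < 0.017 h in this assay, at which 1 of the 2 values shown sits, in this assay, reported as < 0.017 h, a limit rather than a number. The one measured step, an at least 240-fold lower number from compound 1 to compound 2 (2.39 log units; beyond the scatter), places compound 2 at the short-lived end of what is shown. Compound 3 `C=CS(=O)(=O)c1cc(C(F)(F)F)cc(C(F)(F)F)c1` differs from compound 2 by vinylsulfonyl in place of (vinylcarbonyl)oxy on an aromatic carbon. For the measured compounds named here, the step of an at least 240-fold lower number from compound 1 to compound 2 (2.39 log units; beyond the scatter) introduced the very group that now leaves, so it is the only measured step that bears on this change, and a large rise is expected. The estimate for compound 3 is accordingly an at least 1100-fold higher number from compound 2 to compound 3 (3.07 log units; beyond the scatter), to an expected 20 h, between 2 h and 72 h.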

Compound 3, half-life: < 0.017 h
Compound 3: only a limit was reported; the forecaster's own chance of this, stated with the estimate: 40%; middle value at least 1100-fold (3.07 log units) away from the limit.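

Vinylsulfonyl on this aromatic carbon does not bring back the longer life of compound 1: in this assay compound 3 gives < 0.017 h, a limit and not a number. Against the (vinylcarbonyl)amino group, the change gives an at least 240-fold lower number from compound 1 to compound 3 (2.39 log units; beyond the scatter), so the large drop is no longer confined to (vinylcarbonyl)oxy. The step between the two limited compounds cannot be read, and the short-lived end now holds both: the limit of < 0.017 h in this assay, at which 2 of the 3 values shown sit.

Going by these compounds, how far compound 2 and compound 3 lie apart stays open. So does the place of a (vinylcarbonyl)amino group with a methyl on its nitrogen.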